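This account rests on a few compounds, and the source may have more. Where it says the series, first, only, none or still open, it means among the compounds named here.

Measured compounds:
- compound 1, `N#Cc1ccc(Nc2nccc(OCc3cccc(Cl)c3)n2)cc1`, gives 153000 nM in an ADME assay on MT4 cells (Homo sapiens) for cytotoxicity, read by MTT assay, with a stated time of 5 days; on this read-out higher numbers stand for lower toxicity in this test and lower numbers for higher toxicity in this test
- compound 2, `N#Cc1ccc(Nc2nccc(OCc3ccc(F)cc3)n2)cc1`, gives 81000 nM in this assay
- compound 3, `COc1cccc(COc2ccnc(Nc3ccc(C#N)cc3)n2)c1`, gives 118000 nM in this assay

Compound 1 holds the highest of the three numbers in this assay, but neither neighbour stands apart from it: the change a 1.3-fold lower number from compound 1 to compound 3 (0.11 log units; within the scatter) and the change a 1.9-fold lower number from compound 1 to compound 2 (0.28 log units; within the scatter) both lie within the scatter, so the three compounds cannot be ranked on these data. The unmeasured compound 4, `N#Cc1ccc(COc2ccnc(Nc3ccc(C#N)cc3)n2)cc1`, differs from compound 1 in one place: 4-cyanophenyl in place of 3-chlorophenyl on a saturated chain carbon bound to an oxygen on an aromatic ring. Among the compounds with values here, no measured step brings in a 4-cyanophenyl, so the steps that bear on it are the other exchanges at the same place, the step of a 1.9-fold lower number from compound 1 to compound 2 (0.28 log units; within the scatter), the step of a 1.5-fold higher number from compound 2 to compound 3 (0.16 log units; within the scatter) and the step of a 1.3-fold lower number from compound 1 to compound 3 (0.11 log units; within the scatter), each within the scatter. On that basis no step beyond the scatter is expected in this assay, in either direction. Compound 4 is therefore estimated to give 120000 nM, with a range from 50000 nM to 260000 nM. The expected step is a 1.3-fold lower number from compound 1 to compound 4 (0.11 log units; within the scatter).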

Compound 4, half-maximal cytotoxic concentration: 209000 nM
For compound 4 the middle estimate is 1.7-fold (0.24 log units) below the measured one; the measured number falls inside the stated range.
By their numbers in this assay, from the lowest: compounds 2, 3, 1 and 4 (each within the scatter of the next, the first and the last beyond it).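

In this assay, within the data shown here, the 4-cyanophenyl group gives the first step at this position that goes beyond the scatter, a 2.6-fold higher number from compound 2 to compound 4 (0.41 log units; beyond the scatter), though the step is modest and is seen only against the 4-fluorophenyl group of compound 2. Against the two other groups it stays within the scatter, at a 1.4-fold higher number from compound 1 to compound 4 (0.14 log units; within the scatter) and a 1.8-fold higher number from compound 3 to compound 4 (0.25 log units; within the scatter), so all four substituted phenyl groups remain close together in this read-out, with only compound 2 and compound 4 set apart. Nothing measured here accounts for that one larger step.

The compounds shown leave open what an amine or a carboxylic acid on the phenyl ring would do to this number. They also leave open the effect of a longer chain in place of the saturated chain carbon bound to the oxygen.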